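A Nitrophenyl in Place of a Dichlorophenyl

The source may report more compounds than this note shows. Statements on the series, on what has been measured and on what is new or still open speak of the compounds shown alone.

Measured so far:
compound 1 `O=C(COc1ccc(C(=O)/C=C/c2ccc(Cl)cc2Cl)cc1)N[C@H]1CCOC1=O`: 34400 nM
compound 2 `C=CCc1ccc(OCCSC(=S)N[C@H]2CCOC2=O)c(OC)c1`: > 64000 nM, a limit
compound 3 `CCOc1ccccc1OCCSC(=S)N[C@H]1CCOC1=O`: > 64000 nM, a limit

Of the compounds shown here, three have been tested in a functional assay on MCF7 cells (Homo sapiens) for antiproliferative activity, read by MTT assay, with a stated time of 72 h; a higher number here means a weaker inhibitor, a lower number a stronger inhibitor. Within the data shown here, compound 1 is the only one that gives a number: in this assay compound 1 gives 34400 nM. For compound 2 the result is a limit of the assay, > 64000 nM. For compound 3 the result is likewise a limit, > 64000 nM. This is summed up by the limit of > 64000 nM in this assay, at which 2 of the 3 values shown sit. Among the measured compounds shown here, no two measured compounds differ in a single place, so no measured step is available to lean on.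

Compound 4 `O=C(COc1ccc(C(=O)/C=C/c2cccc([N+](=O)[O-])c2)cc1)N[C@H]1CCOC1=O` has not been measured. It differs from compound 1 in one place: 3-nitrophenyl in place of 2,4-dichlorophenyl on a double-bonded chain carbon bound to a double-bonded chain carbon. For the measured compounds named here, nothing among the measured compounds shows how this exchange acts in this assay. The step expected is a 1.2-fold higher number from compound 1 to compound 4 (0.07 log units; within the scatter), which is no larger than the usual scatter of the assay. For compound 4 the estimate in this assay is 40000 nM, expected to fall between 15000 nM and 100000 nM.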

Compound 4, half-maximal inhibitory concentration: > 64000 nM
Compound 4: only a limit was reported; the forecaster's own chance of this, stated with the estimate: 35%; middle value at least 1.6-fold (0.20 log units) from the limit.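

Among these compounds, at the place on a double-bonded chain carbon bound to a double-bonded chain carbon, the measured pair gives the first step in this set: in this assay, 3-nitrophenyl in place of 2,4-dichlorophenyl gives an at least 1.8-fold higher number from compound 1 to compound 4 (0.26 log units; that floor lies within the scatter). Since that floor lies within the scatter, the pair does not establish a real loss of activity, but it does show that this exchange gives no number lower than that of compound 1. Compound 4 joins the compounds that reach the assay's limit and give no number: the limit of > 64000 nM in this assay, at which 3 of the 4 values shown sit.

Going by these compounds, how far compound 4 actually lies from compound 1 remains open, as does whether the result follows from losing the two chlorines or from gaining the nitro group. It is also unknown how this assay would respond to a ring bearing an amine or a carboxylic acid at this place.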